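A few compounds are considered here, and "the series" means these few. Any claim that something is new, unique, unknown or untested is made for them only; others in the source may bear on it.

Of the compounds shown here, three with a shared core have been tested in a functional assay on NCI-H522 cells (Homo sapiens) for inhibition, read by sulforhodamine B assay, with a stated time of 48 h; on this read-out higher numbers stand for weaker inhibition of growth and lower numbers for stronger inhibition of growth. Compound 1 `COc1ccc(-c2[nH]c3ccccc3c2/C=C(\C#N)S(=O)(=O)c2ccccc2)cc1` gives 3000 nM. Compound 2 `COc1ccc2[nH]c(-c3ccccc3)c(C=C(C#N)C#N)c2c1` gives 4600 nM in this assay. Compound 3 `O=C(/C(=C\c1c(-c2ccccc2)[nH]c2ccccc12)S(=O)(=O)c1ccccc1)c1ccccc1` gives 91800 nM in this assay, the highest of the three numbers and therefore the weakest inhibition of growth among them: its gap to compound 2 and its gap to compound 1 both lie beyond the usual scatter of the measurement.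

Compound 4 `N#C/C(=C\c1c(-c2ccccc2)[nH]c2ccccc12)S(=O)(=O)c1ccccc1` is not yet measured. It differs from compound 3 in one place: cyano in place of benzoyl on a double-bonded chain carbon bound to a double-bonded chain carbon and a sulfonyl sulfur. The same cyano group sits at that place in compound 1, which carries a far lower number than compound 3, so a step from compound 3 to compound 4 toward stronger inhibition of growth, and a large one, is expected in this assay, estimated at a 23-fold lower number from compound 3 to compound 4 (1.36 log units; beyond the scatter). For compound 4 the estimated value in this assay is 4000 nM, with a range from 1500 nM to 15000 nM.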

Compound 4, concentration for 50% growth inhibition: 4600 nM
The estimate for compound 4 lay 1.2-fold (0.06 log units) below the measured number; the measured number falls inside the stated range.
By their numbers in this assay, from the lowest: compounds 1, 2 and 4 (each within the scatter of the next); then compound 3.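

In this assay, for the compounds shown here, cyano in place of benzoyl on a double-bonded chain carbon bound to a double-bonded chain carbon and a sulfonyl sulfur gives a 20-fold lower number from compound 3 to compound 4 (1.30 log units; beyond the scatter), the first reading of this change with the rest of the structure held constant. Hydrogen in place of methoxy on an aromatic carbon gives a 1.5-fold higher number from compound 1 to compound 4 (0.19 log units; within the scatter), so these two compounds cannot be told apart in this assay, and methoxy at that carbon shows no measurable effect here. Nothing available explains why the benzoyl and cyano compounds differ so widely.

From the compounds shown here alone, only benzoyl and cyano can be compared at this chain carbon, so it remains open whether a methyl ester or a primary amide there would read like cyano or like benzoyl. Going by these compounds, it is equally open whether a chlorine or a dimethylamino group on the aromatic carbon would also leave the number within the scatter.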